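From ethoxycarbonyl to carboxy in compound 3

The compounds below may be only part of what the source reports. "The series", "measured", "known", "first", "only" and "open" are said of these compounds alone.

- compound 1 `CCOC(=O)/C(=C\c1cccc(OCC(=O)OC(C)(C)C)c1)c1nc(-c2ccccc2)c(-c2ccccc2)o1`: > 60000 nM (a limit, not a number)
- compound 2 `CCOC(=O)/C(=C\c1cccc(OCC(=O)O)c1)c1nc(-c2ccccc2)c(-c2ccccc2)o1`: 360 nM

Going by the values given here, in a functional assay for inhibition, with Homo sapiens as the target (on this read-out lower numbers stand for stronger inhibition and higher numbers for weaker inhibition), compound 2 gives 360 nM as the only true number so far. Compound 3 `O=C(O)COc1cccc(/C=C(\C(=O)O)c2nc(-c3ccccc3)c(-c3ccccc3)o2)c1` differs from it by one change (hydrogen in place of ethyl on an oxygen next to a carbonyl group), which turns ethoxycarbonyl into carboxy. Among the compounds with values here, the one measured step that bears on this is the same kind of swap made elsewhere in the molecule, hydrogen in place of tert-butyl (an at least 160-fold lower number from compound 1 to compound 2 (2.22 log units; beyond the scatter)) and it was large. That step rests on a limit (the limit of > 60000 nM in this assay, at which 1 of the 2 values shown sits) at compound 1. Compound 2 (360 nM) already carries the carboxy group gained in that step, so no repeat of the large fall is expected in this assay, and a moderate rise in the number is expected instead. That estimated change reads (a 3.3-fold higher number from compound 2 to compound 3 (0.52 log units; beyond the scatter)) and its direction is uncertain. Compound 3 is thus expected at 1200 nM within a range of 250 nM to 8000 nM as an estimate.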

Compound 3, half-maximal inhibitory concentration: 20300 nM
Compound 3: middle estimate off by 17-fold (1.23 log units), on the low side; measured number outside the range, above it.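

Hydrogen in place of ethyl on an oxygen next to a carbonyl group gives a 56-fold higher number from compound 2 to compound 3 (1.75 log units; beyond the scatter) in this assay, so at this position the free carboxy group goes with much weaker inhibition. The same kind of swap made elsewhere in the molecule, hydrogen in place of tert-butyl, gave an at least 160-fold lower number from compound 1 to compound 2 (2.22 log units; beyond the scatter), so in these compounds the direction of the change depends on where it is made. Compound 1 stands at a limit and not at a true number, which makes the size of that earlier step a bound only: the limit of > 60000 nM in this assay, at which 1 of the 3 values shown sits.

Only ethoxycarbonyl and carboxy are shown at this position, so it remains open whether a methyl ester, a longer chain on the ester or an amide would match compound 2. The compounds shown also do not tell why the number rises here.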